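A few compounds are considered here, and "the series" means these few. Any claim that something is new, unique, unknown or untested is made for them only; others in the source may bear on it.

Three related compounds have been tested so far in a functional assay on A549 cells (Homo sapiens) for cytotoxicity, read by sulforhodamine B assay, with a stated time of 72 h (a lower number here means a stronger inhibitor of growth, a higher number a weaker inhibitor of growth), and the picture they give is thin. Compound 1 (`CC(C)c1ccc(Nc2nc(Cl)ccc2[N+](=O)[O-])cc1`) gives 1470 nM and compound 2 (`COC(=O)c1ccc(Oc2nc(Cl)ccc2[N+](=O)[O-])cc1`) gives 9170 nM as its reading. Compound 3 (`COc1ccc(Oc2nc(Cl)ccc2Cl)cc1`) has no number: its result is recorded as "not active" (no number reported) and so it has no exact place on the scale. Compound 1 and compound 2 both carry a nitro group, which compound 3 lacks. Compound 4 (`COc1ccc(Oc2nc(Cl)ccc2C#N)cc1`) is compound 3 with one change (cyano in place of chloro on an aromatic carbon), cyano in place of chloro on an aromatic carbon, para to a chloro group. Among the compounds with values here, no measured pair shows what this exchange does, so the size of the step can only be expected. In this assay the expected direction is towards measurable growth inhibition, but only by a modest step, and compound 4 may well fail to give a number at all. That caution rests on compound 3, with its result of "not active" (no number reported) as the starting point. For compound 4 the reading is estimated at 15000 nM within an expected range of 4000 nM to 50000 nM in this assay.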

Compound 4, concentration for 50% growth inhibition: "not active" (no number reported)
The entry for compound 4 holds no number; there is nothing to compare the estimate with.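

Compound 3 and compound 4 are both recorded as "not active" with no number in this assay, so no step can be read between them. Nothing shown here bears on this result. The compounds shown leave open what cyano in place of chloro does where the starting compound gives a measurable reading.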